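Adding one methyl to compound 1

The source may report more compounds than this note shows. Statements on the series, on what has been measured and on what is new or still open speak of the compounds shown alone.

Measured so far in an ADME assay on MT4 cells (Homo sapiens) for cytotoxicity, read by MTT assay, with a stated time of 4 days; a lower number here means that less compound is tolerated, a higher number that more compound is tolerated (each entry is a limit, not a number):
- compound 1 `Cc1c(Cc2c(F)cccc2F)nc(N(C)C)[nH]c1=O` gives > 89000 nM
- compound 2 `Cc1c(Cc2c(F)cccc2F)nc(N2CCCCCC2)[nH]c1=O` gives > 75000 nM
- compound 3 `Cc1c(Cc2c(F)cccc2F)nc(N2CCN(C)CC2)[nH]c1=O` gives > 75000 nM

Compound 1 stands only at a limit, > 89000 nM, and no exact number is known for it. Compound 4 `Cc1c(C(C)c2c(F)cccc2F)nc(N(C)C)[nH]c1=O` has not been measured. It carries methyl in place of hydrogen on a saturated chain carbon bound to two aromatic carbons, (methyl in place of hydrogen on a saturated chain carbon bound to two aromatic carbons), and is otherwise the same as compound 1.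

The measured steps all swap the amino group instead: a step that the two limits leave unreadable from compound 1 to compound 2, a step that the two limits leave unreadable from compound 1 to compound 3 and a step that the two limits leave unreadable from compound 2 to compound 3. None of them touches the place of the new methyl, and none has a readable size. They therefore bear on it only loosely, as signs that these changes have not brought a number into view. No step beyond the scatter is expected in this assay, in either direction, and compound 4 will probably also be reported as a limit. The expected change is an at least 1.0-fold lower number from compound 1 to compound 4 (0.01 log units; that floor lies within the scatter). For compound 4 the estimated value is 85000 nM, with an expected range from 40000 nM to 180000 nM.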

Compound 4, half-maximal cytotoxic concentration: > 17000 nM
Compound 4 gave a limit, no number (the forecaster's own chance of this, stated with the estimate: 80%); the middle value lies beyond the limit too.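

Compound 1 and compound 4 are both reported only as limits, and the step between them cannot be read. The compounds shown leave open where any exact value lies in this assay, and whether the added methyl changes that value at all.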